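A few compounds are considered here, and "the series" means these few. Any claim that something is new, unique, unknown or untested is made for them only; others in the source may bear on it.

Compound 1 `COc1cc2c(Oc3ccc(NC(=O)c4nnn(-c5ccccc5)c4C)cc3F)ccnc2cc1OCCCN1CCCC1` and compound 2 `COc1cc2c(Oc3ccc(NC(=O)c4nnn(-c5ccc(F)cc5)c4C(F)(F)F)cc3F)ccnc2cc1OCCCN1CCCC1` share one core and differ on the phenyl attached to the triazole and in the group next to the amide. In a functional assay on NCI-H460 cells (Homo sapiens) for cytotoxicity, read by MTT assay, with a stated time of 72 h (on this read-out higher numbers stand for weaker inhibition and lower numbers for stronger inhibition), compound 1 gives 160 nM, and in this assay compound 2 gives 150 nM, the lower of the two numbers, with the gap to compound 1 inside the scatter. Compound 3 `COc1cc2c(Oc3ccc(NC(=O)c4nnn(-c5ccc(C)cc5)c4C(F)(F)F)cc3F)ccnc2cc1OCCCN1CCCC1` differs from compound 2 by methyl in place of fluoro on an aromatic carbon. Within the data shown here, no measured pair shows this change; the step is expected to stay within the scatter, in no fixed direction, as no change at the digits printed from compound 2 to compound 3 (within the scatter). Compound 3 is therefore expected to give 150 nM in this assay, in a range from 70 nM to 320 nM.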

Compound 3, half-maximal inhibitory concentration: 790 nM
Beside the measured number, compound 3's estimate is 5.3-fold (0.72 log units) below it; the whole stated range lies below it.
By their numbers in this assay, from the lowest: compounds 2 and 1 (each within the scatter of the next); then compound 3.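

In this assay, among these compounds, going from 4-fluorophenyl to 4-methylphenyl gives a 5.3-fold higher number from compound 2 to compound 3 (0.72 log units; beyond the scatter) and is the first single-place step. At this aromatic carbon, exchanging one heavy atom for another, with no ring, hydrogen-bond donor, hydrogen-bond acceptor or net charge involved, is enough to move the number beyond the scatter. No measurement at hand speaks to the reason for this step.

From the compounds shown here alone, whether a chloro, methoxy or amine group here would track compound 2 or compound 3 stays open. So does whether this step would keep its size without the trifluoromethyl group of both compounds.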